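Cytotoxicity notes on a fused bicyclic acetal series

The source may hold more compounds than are shown below. What is called first, only, known or untested is meant among the compounds shown, and "the series" means these compounds.

Measured compounds:
compound 1 `O[C@@H]1[C@@H](O)[C@H](c2ccccc2)O[C@@H]2CO[C@@H](c3ccc(C(F)(F)F)cc3)O[C@@H]12` — 400 ug/mL
compound 2 `CO[C@@H]1[C@@H](OC)[C@H](c2ccccc2)O[C@@H]2CO[C@@H](c3ccc(C)cc3)O[C@@H]12` — "not determined" (no result reported)
compound 3 `CO[C@@H]1[C@@H](OC)[C@H](c2ccccc2)O[C@@H]2CO[C@@H](c3ccc4ccccc4c3)O[C@@H]12` — to be measured

In a functional assay on HEL cells (Homo sapiens) for cytotoxicity (on this read-out lower numbers stand for higher toxicity in this test and higher numbers for lower toxicity in this test), compound 1 gives 400 ug/mL. For compound 2 the same read-out was not determined, so compound 2 stands without a number in this assay; what can be said of it rests on its structure alone. Within the data shown here, compound 2 and compound 1 share the core of compound 1 but differ at more than one place, so no single step between them can be drawn.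

Compound 3 is derived from compound 2 by one change: naphthalen-2-yl in place of 4-methylphenyl on a saturated ring carbon. Among the measured compounds shown here, no measured pair shows what this change does in this assay. For the measured compounds named here, with the only number coming from compound 1, the expectation is a small shift in this assay, if any, toward lower numbers, likely within the scatter of the method. Compound 3 is therefore expected to give about 200 ug/mL, within a range of 50 ug/mL to 400 ug/mL.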

Compound 3, minimum cytotoxic concentration: >= 16 ug/mL
Compound 3 was reported as a limit (the forecaster's own chance of this, stated with the estimate: 30%); the middle value lies beyond the limit too.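

In this assay compound 3 gives >= 16 ug/mL, which is a limit and not a number. No step can be read between compound 2 and compound 3, as compound 2 has no number to set against that limit. Going by these compounds, what naphthalen-2-yl in place of 4-methylphenyl does on this read-out remains open.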